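The source may report more compounds than this note shows. Statements on the series, on what has been measured and on what is new or still open speak of the compounds shown alone.

Of the compounds shown here, three built on one shared core have been tested in a functional assay on CAKI-1 cells (Homo sapiens) for cytotoxicity, read by sulforhodamine B assay; a higher number here means a weaker inhibitor, a lower number a stronger inhibitor. Compound 1 `COc1ccc(-c2cc3cc(C)ccc3c(N)n2)cc1OC` gives 510 nM in this assay. Compound 2 `COc1cc(OC)cc(-c2cc3cc(OC)c(OC)cc3c(N)n2)c1` gives 540 nM in this assay, and these two values lie within the usual scatter of each other. Compound 3 `CN(C)c1cccc2c(N)nc(-c3ccccc3)cc12` stands apart: in this assay compound 3 gives > 10000 nM, which is a limit of the assay and not a number. Among the three values, one sits at that limit (the limit of > 10000 nM in this assay, at which 1 of the 3 values shown sits), so where compound 3 truly stands on the scale is not known.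

The next compound, compound 4 `Cc1ccccc1-c1cc2c(N(C)C)cccc2c(N)n1`, differs from compound 3 only by methyl in place of hydrogen on an aromatic carbon. Going by the values given here, no measured pair of compounds shows what this change does in this assay, so its effect can only be expected. The step that the limit leaves unreadable from compound 3 to compound 4 is expected to be none beyond the scatter. Compound 4 is therefore estimated at 15000 nM in this assay, within a range from 3000 nM to 60000 nM, and quite possibly only a limit will be reported again.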

Compound 4, half-maximal inhibitory concentration: > 10000 nM
Compound 4: only a limit was reported; the forecaster's own chance of this, stated with the estimate: 60%; the middle value lies beyond the limit too.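

Compound 3 and compound 4 both end at a limit of the assay rather than a number, so no step can be read between them: the limit of > 10000 nM in this assay, at which 2 of the 4 values shown sit.

The compounds shown leave open what methyl in place of hydrogen on an aromatic carbon does in this assay, and where compound 3 and compound 4 truly stand on its scale.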